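This account rests on a few compounds, and the source may have more. Where it says the series, first, only, none or still open, it means among the compounds named here.

Measured compounds:
compound 1 `CC(C)(C)c1ccc(NC(=O)c2ccc(-c3ccccn3)cc2)cc1`, a functional assay for antagonist activity at transient receptor potential cation channel subfamily V member 1 (Homo sapiens), read by FLIPR (a lower number here means a stronger inhibitor, a higher number a weaker inhibitor), 11 nM
compound 2 `CC(C)(C)c1ccc(NC(=O)c2ccc(-c3ncccc3C#N)cc2)cc1`, this assay 30 nM
compound 3 `CC(C)(C)c1ccc(NC(=O)c2ccc(-c3ncccc3NS(=O)(=O)c3ccccc3)cc2)cc1`, this assay 91 nM

Compound 3 gives the highest number of the three, standing at a 3.0-fold higher number from compound 2 to compound 3 (0.48 log units; beyond the scatter) and at an 8.3-fold higher number from compound 1 to compound 3 (0.92 log units; beyond the scatter), both beyond the scatter. Compound 4 `CN(C)Cc1cccnc1-c1ccc(C(=O)Nc2ccc(C(C)(C)C)cc2)cc1` differs from compound 3 in one place: (dimethylamino)methyl in place of (phenylsulfonyl)amino on an aromatic carbon.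

Among the measured compounds shown here, two steps bear on the change. Putting cyano in place of hydrogen gave a 2.7-fold higher number from compound 1 to compound 2 (0.44 log units; beyond the scatter); putting (phenylsulfonyl)amino in place of hydrogen gave an 8.3-fold higher number from compound 1 to compound 3 (0.92 log units; beyond the scatter); and moving from cyano to (phenylsulfonyl)amino gave a 3.0-fold higher number from compound 2 to compound 3 (0.48 log units; beyond the scatter). Each group entering on that aromatic carbon has raised the number, with the larger group raising it more. (Dimethylamino)methyl is counted at 4 heavy atoms, between cyano and (phenylsulfonyl)amino in size, and the expected result is a number between those of compound 2 and compound 3. Compound 4 is therefore expected to give 45 nM in this assay, with a range of 15 nM to 140 nM, which amounts to an estimated 2.0-fold lower number from compound 3 to compound 4 (0.31 log units; beyond the scatter).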

Compound 4, half-maximal inhibitory concentration: 746 nM
For compound 4 the middle estimate is 17-fold (1.22 log units) below the measured one, outside the stated range (above it).
By their numbers in this assay, from the lowest: compound 1; then compound 2; then compound 3; then compound 4.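

In this assay the rise in the number with the size of the entering group does not hold at this aromatic carbon, and compound 4 goes against it: an 8.2-fold higher number from compound 3 to compound 4 (0.91 log units; beyond the scatter) came with (dimethylamino)methyl, of 4 heavy atoms, replacing (phenylsulfonyl)amino, of 10 heavy atoms. The other two steps, a 25-fold higher number from compound 2 to compound 4 (1.40 log units; beyond the scatter) and a 68-fold higher number from compound 1 to compound 4 (1.83 log units; beyond the scatter), show that compound 4 gives the highest number of the four and so is the weakest inhibitor shown. The change also removes a six-membered aromatic ring and the hydrogen-bond donor, but this one compound cannot separate those differences from one another.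

No measurement shown gives a reason for this rise. Going by these compounds, it remains open whether a methyl, hydroxymethyl or aminomethyl group on this carbon would give a number nearer that of compound 2 or that of compound 4.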